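Amide tail truncation in the chloro-methoxyphenyl pyrazole series

This account rests on a few compounds, and the source may have more. Where it says the series, first, only, none or still open, it means among the compounds named here.

Measured compounds:
compound 1, `COc1cc(-c2nn(-c3cccc(NC(=O)Nc4cccc(C(F)(F)F)c4)c3)cc2-c2ccncc2)ccc1Cl`, 1180 nM
compound 2, `COc1cc(-c2nn(-c3cccc(NC(=O)c4ccc(Cl)c(C(F)(F)F)c4)c3)cc2-c2ccncc2)ccc1Cl`, 5390 nM

Compound 2 holds the highest number of the two measured in a functional assay on NCI-H23 cells (Homo sapiens) for inhibition, read by sulforhodamine B assay, with a stated time of 48 h; on this read-out lower numbers stand for stronger inhibition of growth and higher numbers for weaker inhibition of growth; its nearest neighbour is compound 1, reached by a 4.6-fold higher number from compound 1 to compound 2 (0.66 log units; beyond the scatter). Compound 3, `COc1cc(-c2nn(-c3cccc(NC(=O)c4ccccc4)c3)cc2-c2ccncc2)ccc1Cl`, differs from compound 2 by phenyl in place of 4-chloro-3-(trifluoromethyl)phenyl on a carbonyl carbon.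

Among the compounds with values here, no measured step touches the same place: the only step recorded, from compound 1 to compound 2, exchanges the whole group on the carbonyl carbon together with the amide-type nitrogen link, so it gives no direct guide for removing the chlorine and trifluoromethyl alone. Both measured values sit in the micromolar range in this assay, and the change to compound 3 is taken to leave the number at that level or move it modestly higher. Compound 3 is therefore expected at 9000 nM, within 3000 nM to 30000 nM, a step of a 1.7-fold higher number from compound 2 to compound 3 (0.22 log units; within the scatter).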

Compound 3, concentration for 50% growth inhibition: 2020 nM
Beside the measured number, compound 3's estimate is 4.5-fold (0.65 log units) above it, outside the stated range (below it).
By their numbers in this assay, from the lowest: compounds 1 and 3 (each within the scatter of the next); then compound 2.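

In this assay the exchange of 4-chloro-3-(trifluoromethyl)phenyl for phenyl on a carbonyl carbon gives a 2.7-fold lower number from compound 2 to compound 3 (0.43 log units; beyond the scatter) and so shows that, at this place, growth inhibition does not depend on the chlorine and trifluoromethyl pair. Compound 3 also stands level with compound 1, at a 1.7-fold higher number from compound 1 to compound 3 (0.23 log units; within the scatter) and thus within the scatter, so the (3-(trifluoromethyl)phenyl)amino group shows no measurable gain over plain phenyl on this carbonyl carbon. No measurement at hand accounts for either step.

The compounds shown leave open whether the chlorine or the trifluoromethyl alone goes with the weaker number of compound 2, since neither appears alone on the phenyl of this amide. Also open, from the compounds shown here alone, is how an amine, a carboxylic acid or a longer alkyl chain on the phenyl would read here.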